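Replacing 6-(thiophen-2-yl)pyridin-3-yl with 2-aminophenyl

This account rests on a few compounds, and the source may have more. Where it says the series, first, only, none or still open, it means among the compounds named here.

Measured in a functional assay on G-361 cells (Homo sapiens) for inhibition, with a stated time of 72 h; a higher number here means a weaker inhibitor, a lower number a stronger inhibitor
- compound 1 `NC1CCC(Nc2nc(NCc3ccc(-c4ccccc4)cc3)c3ncn(C4CCCC4)c3n2)CC1` (1020 nM)
- compound 2 `NC1CCC(Nc2nc(NCc3ccc(-c4ccccc4)nc3)c3ncn(C4CCCC4)c3n2)CC1` (895 nM)
- compound 3 `NC1CCC(Nc2nc(NCc3ccc(-c4cccs4)nc3)c3ncn(C4CCCC4)c3n2)CC1` (150 nM)

Compound 3 has the lowest number of the three, and its steps to both others lie beyond the scatter. Unmeasured compound 4 `Nc1ccccc1CNc1nc(NC2CCC(N)CC2)nc2c1ncn2C1CCCC1` carries 2-aminophenyl in place of 6-(thiophen-2-yl)pyridin-3-yl on a saturated chain carbon bound to a nitrogen on an aromatic ring. The bearing steps are (a 6.8-fold lower number from compound 1 to compound 3 (0.83 log units; beyond the scatter)) and (a 6.0-fold lower number from compound 2 to compound 3 (0.78 log units; beyond the scatter)), while (a 1.1-fold lower number from compound 1 to compound 2 (0.06 log units; within the scatter)) stays within the scatter. None of them tests 2-aminophenyl, so the expectation is loose. A modest rise in this assay is expected (a 4.0-fold higher number from compound 3 to compound 4 (0.60 log units; beyond the scatter)). Compound 4 is estimated at 600 nM (range 150 nM to 2500 nM).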

Compound 4, half-maximal inhibitory concentration: 2070 nM
Estimate against measurement, compound 4: 3.5-fold (0.54 log units) below, within the range that was stated.
By their numbers in this assay, from the lowest: compound 3; then compounds 2 and 1 (each within the scatter of the next); then compound 4.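

In this assay, the single-ring 2-aminophenyl at this place, on a saturated chain carbon bound to a nitrogen on an aromatic ring, gives the highest number of the series (a 14-fold higher number from compound 3 to compound 4 (1.14 log units; beyond the scatter)). The other two steps to it are smaller but also beyond the scatter (a 2.3-fold higher number from compound 2 to compound 4 (0.36 log units; beyond the scatter); a 2.0-fold higher number from compound 1 to compound 4 (0.31 log units; beyond the scatter)), so all three two-ring groups give lower numbers than this one. Nothing available gives a reason for the rise.

Compound 4 changes the ring count and adds the amine together, and the two stay unseparated. A plain phenyl or a lone thiophen-2-yl at this place would separate them.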